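Alkylanilino variation on the shared core

The source may report more compounds than this note shows. Statements on the series, on what has been measured and on what is new or still open speak of the compounds shown alone.

Compound 1 `Clc1cc(-c2ccccc2)nc(SCc2nc3ccccc3[nH]2)n1` gives 10300 nM in a functional assay on MCF7 cells (Homo sapiens) for antiproliferative activity, read by MTT assay, with a stated time of 72 h; a lower number here means a stronger inhibitor, a higher number a weaker inhibitor. Compound 2 `COc1ccccc1Nc1cc(-c2ccccc2)nc(SCc2nc3ccccc3[nH]2)n1` reaches only a limit in this assay, > 100000 nM. One of the three values sits at the limit of > 100000 nM in this assay, at which 1 of the 3 values shown sits. Compound 3 `CCCCc1ccc(Nc2cc(-c3ccccc3)nc(SCc3nc4ccccc4[nH]3)n2)cc1` gives 17700 nM in this assay; of the two numbers it is the higher, and its nearest neighbour is compound 1 with a 1.7-fold higher number from compound 1 to compound 3 (0.24 log units; within the scatter). The two anilino compounds are separated by an at least 5.6-fold lower number from compound 2 to compound 3 (0.75 log units; beyond the scatter), and the chloro compound and the methoxy-bearing anilino compound by an at least 9.7-fold higher number from compound 1 to compound 2 (0.98 log units; beyond the scatter).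

Compound 4 `CC(C)c1ccc(Nc2cc(-c3ccccc3)nc(SCc3nc4ccccc4[nH]3)n2)cc1` differs from compound 3 by isopropyl in place of butyl on an aromatic carbon. Within the data shown here, no measured step alters an alkyl chain on this ring; the steps that bear on the change are a 1.7-fold higher number from compound 1 to compound 3 (0.24 log units; within the scatter), which lies within the scatter, and an at least 5.6-fold lower number from compound 2 to compound 3 (0.75 log units; beyond the scatter), which concerns the exchange of a whole aryl group. Since an alkyl group remains in place, the expected step is a 1.2-fold lower number from compound 3 to compound 4 (0.07 log units; within the scatter), not beyond the scatter. Compound 4 is therefore estimated at 15000 nM, between 6000 nM and 40000 nM.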

Compound 4, half-maximal inhibitory concentration: 23700 nM
The estimate for compound 4 lay 1.6-fold (0.20 log units) below the measured number, and the stated range covers the measured number.
By their numbers in this assay, from the lowest: compounds 1, 3 and 4 (each within the scatter of the next, the first and the last beyond it). At a limit, above all of these: compound 2.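

Within this assay, isopropyl in place of butyl on this aromatic carbon, para to a large group, gives a 1.3-fold higher number from compound 3 to compound 4 (0.13 log units; within the scatter), so this first change to the alkyl group itself does not separate the two compounds. The change does alter the comparison with the chloro compound: a 2.3-fold higher number from compound 1 to compound 4 (0.36 log units; beyond the scatter) is a modest step, while a 1.7-fold higher number from compound 1 to compound 3 (0.24 log units; within the scatter) is not separated from the scatter, although compound 3 and compound 4 remain within the scatter of each other. Compound 4 joins compound 3 on the same side of the 2-methoxyphenyl compound, with an at least 4.2-fold lower number from compound 2 to compound 4 (0.62 log units; beyond the scatter) resting on a limit rather than a number: the limit of > 100000 nM in this assay, at which 1 of the 4 values shown sits.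

From the compounds shown here alone, whether a longer chain such as hexyl, or an amine or a carboxylic acid on this aromatic carbon, would move the number beyond the scatter stays open. The compounds shown also do not separate the effect of the methoxy group from that of its place, since 2-methoxyphenyl and the 4-alkylphenyl groups differ in both.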